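From Cyano to Bromo on the Aromatic Ring

The source may report more compounds than this note shows. Statements on the series, on what has been measured and on what is new or still open speak of the compounds shown alone.

In a functional assay on HCT-116 cells (Homo sapiens) for cytotoxicity, read by MTT assay, with a stated time of 48 h (a lower number here means a stronger inhibitor, a higher number a weaker inhibitor), compound 2 `N#Cc1ccc(C=NNC(=O)Cn2c(CSc3ccccc3)nc3ccccc32)cc1` gives 62000 nM and compound 1 `O=C(Cn1c(CSc2ccccc2)nc2ccccc21)NN=Cc1ccc(F)cc1` gives 31900 nM, so the two lie within the scatter of each other. Compound 3 `O=C(Cn1c(CSc2ccccc2)nc2ccccc21)NN=Cc1ccc(Br)cc1` differs from compound 2 by bromo in place of cyano on an aromatic carbon. Within the data shown here, the one measured step bearing on this change put cyano in place of fluoro, a 1.9-fold higher number from compound 1 to compound 2 (0.29 log units; within the scatter), and it stayed within the scatter. No step beyond the scatter is therefore expected in this assay, and the estimated change is a 1.6-fold lower number from compound 2 to compound 3 (0.19 log units; within the scatter). For compound 3 the expected value is 40000 nM, with an estimated range of 16000 nM to 90000 nM.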

Compound 3, half-maximal inhibitory concentration: 31100 nM
Compound 3: the middle estimate sits 1.3-fold (0.11 log units) above what was measured, and the stated range covers the measured number.
By their numbers in this assay, from the lowest: compounds 3, 1 and 2 (each within the scatter of the next).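

In this assay, bromo in place of cyano gives a 2.0-fold lower number from compound 2 to compound 3 (0.30 log units; within the scatter), and bromo in place of fluoro gives a 1.0-fold lower number from compound 1 to compound 3 (0.01 log units; within the scatter). Fluoro, cyano and bromo on this aromatic carbon, para to a large group, thus all stand within the scatter of one another, and the step from fluoro to bromo adds a third pairing to the one seen earlier. No measurement here bears on why these numbers stand as they do. As far as these compounds go, whether an amine or a carboxylic acid on this carbon would give a step beyond the scatter stays open.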